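The compounds below may be only part of what the source reports. "The series", "measured", "known", "first", "only" and "open" are said of these compounds alone.

Series notes, cytotoxicity. In an ADME assay on HEp-2 cells (Homo sapiens) for cytotoxicity, with a stated time of 4 days (a lower number here means that less compound is tolerated, a higher number that more compound is tolerated), compound 1 `CS(=O)(=O)CCn1c(Cn2cc(S(C)(=O)=O)c3ccccc32)nc2cc(Cl)ccc21` gives > 100000 nM, which is a limit of the assay and not a number. Compound 2 `CS(=O)(=O)CCCn1c(Cn2cc(S(C)(=O)=O)c3ccccc32)nc2cc(Cl)ccc21` gives > 100000 nM in this assay, again a limit rather than a number. Compound 3 `CS(=O)(=O)CCCn1c(Cn2nc(S(C)(=O)=O)c3ccncc32)nc2cc(Cl)ccc21` gives > 100000 nM in this assay, also a limit. Among the measured compounds shown here, the one step between measured compounds differing in a single place is a step that the two limits leave unreadable from compound 1 to compound 2. Compound 3 thus stands where every measured value of the set stands, at the limit of > 100000 nM in this assay, at which 3 of the 3 values shown sit; nothing in the numbers separates it from compound 1 or compound 2.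

Compound 4 `CS(=O)(=O)c1nn(Cc2nc3cc(Cl)ccc3n2CCC(O)C(F)(F)F)c2cnccc12` differs from compound 3 by 2,2,2-trifluoro-1-hydroxyethyl in place of (methylsulfonyl)methyl on a saturated chain carbon, two bonds along the chain from an aromatic nitrogen. For the measured compounds named here, no measured step covers this exchange; the only step available, from compound 1 to compound 2, is itself unreadable between two limits and bears on it only as a change at the same place on the chain. With three of three values at the limit and no readable step, the expected step in this assay is a number no higher from compound 3 to compound 4 (the limit leaves the size open), none beyond the scatter, and compound 4 is expected to return a limit as well. The estimate for compound 4 is 100000 nM, with a range from 50000 nM to 300000 nM.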

Compound 4, half-maximal cytotoxic concentration in the HEp-2 assay: > 100000 nM
Compound 4: no number, only a limit; the forecaster's own chance of this, stated with the estimate: 85%; the middle value lies on the limit itself.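

In the HEp-2 assay compound 3 gives > 100000 nM as a limit of the assay and not a number. In the HEp-2 assay compound 4 gives > 100000 nM as a limit of the assay and not a number. Compound 3 and compound 4 both return only a limit in the HEp-2 assay so no step can be read between them: the limit of > 100000 nM in the HEp-2 assay, at which 4 of the 4 values shown sit.

The compounds shown leave open at what concentration any of them becomes cytotoxic, and whether 2,2,2-trifluoro-1-hydroxyethyl in place of (methylsulfonyl)methyl changes that concentration at all.

In a physicochemical assay for solubility, read by spectrophotometry, in phosphate buffer, at pH 6.5 (on this read-out higher numbers stand for higher solubility and lower numbers for lower solubility), compound 3 gives 2 ug/mL as a measured number. In the physicochemical assay compound 4 gives < 1 ug/mL as a limit of the assay and not a number. In the physicochemical assay the step is an at least 2.0-fold lower number from compound 3 to compound 4 (0.30 log units; that floor lies within the scatter) and it rests on that limit.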